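Working notes: nitro in place of chloro

The source may report more compounds than this note shows. Statements on the series, on what has been measured and on what is new or still open speak of the compounds shown alone.

- compound 1 `O=C(OCCCc1cccnc1)C1CCCCN1S(=O)(=O)Cc1cccc([N+](=O)[O-])c1`: 46700 nM
- compound 2 `O=C(OCCCc1cccnc1)[C@@H]1CCCCN1S(=O)(=O)Cc1cccc(Cl)c1`: 43300 nM

In a toxicity assay (J774.1 cells) for cytotoxicity, with Mus musculus as the target, read by resazurin assay, with a stated time of 24 h (on this read-out higher numbers stand for weaker inhibition and lower numbers for stronger inhibition), compound 2 gives 43300 nM, within the scatter of compound 1 at 46700 nM. Compound 3 `O=C(OCCCc1cccnc1)[C@@H]1CCCCN1S(=O)(=O)Cc1cccc([N+](=O)[O-])c1` has nitro in place of chloro on an aromatic carbon of compound 2 (nitro in place of chloro on an aromatic carbon), the change from 3-chlorobenzyl to 3-nitrobenzyl. Within the data shown here, no measured step covers this change. Compound 1 also carries the nitro group and gives 46700 nM, so no shift beyond the scatter is expected in this assay. The step of a 1.0-fold higher number from compound 2 to compound 3 (0.02 log units; within the scatter) is expected to be small. For compound 3 the estimated value is 45000 nM, with an expected range of 25000 nM to 80000 nM.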

Compound 3, half-maximal inhibitory concentration: 48200 nM
Beside the measured number, compound 3's estimate is 1.1-fold (0.03 log units) below it, and the stated range covers the measured number.
By their numbers in this assay, from the lowest: compounds 2, 1 and 3 (each within the scatter of the next).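

In this assay, the exchange of chloro for nitro on the aromatic carbon gives a 1.1-fold higher number from compound 2 to compound 3 (0.05 log units; within the scatter), so 3-chlorobenzyl and 3-nitrobenzyl cannot be told apart on this read-out. The second pair gives a 1.0-fold higher number from compound 1 to compound 3 (0.01 log units; within the scatter), also within the scatter, and it turns on a single feature: the fact that one of compounds 1 and 3 is drawn with a defined configuration and the other without, at the place where they differ.

The compounds shown leave open whether an amine or a carboxylic acid on the same aromatic carbon would read alike. They also leave open how the opposite drawn configuration at the saturated ring carbon would read.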